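From Ethyl to Fluoro in a Growth Inhibition Assay

The source may report more compounds than this note shows. Statements on the series, on what has been measured and on what is new or still open speak of the compounds shown alone.

Going by the values given here, in a functional assay on SMMC-7721 cells (Homo sapiens) for inhibition, read by CCK-8 assay, with a stated time of 72 h, tested at 2 uM (a higher number here means more inhibition of growth at the concentration tested, a lower number less inhibition of growth), compound 1 (`CCc1ccc(SCc2ccc(C(=O)Nc3ccccc3N)cc2)cc1`) gives 25.7% of inhibition, the higher of the two numbers so far. Compound 2 (`Nc1ccccc1NC(=O)/C=C/c1ccc(CSCCc2ccccc2)cc1`) gives 14.7% in this assay and lies lower by more than the usual scatter. Compound 3 (`Nc1ccccc1NC(=O)c1ccc(CSc2ccc(F)cc2)cc1`) has not yet been measured. It carries fluoro in place of ethyl on an aromatic carbon para to a large group. Among the compounds with values here, the two measured compounds differ in more than one place, so no measured step speaks to this change. The expectation therefore starts from compound 1 at 25.7% as the closest measured structure. No change beyond the scatter is expected, with the estimated step of a number 3.7 percentage points lower from compound 1 to compound 3 (within the scatter) pointing slightly downward. The expected value for compound 3 is 22% within an estimated range from 8% to 40% in this measurement.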

Compound 3, percent growth inhibition at one concentration: 6.58%
The estimate for compound 3 lay 15.4 percentage points above the measured number; the whole stated range lies above it.
By their numbers in this assay, from the lowest: compounds 3 and 2 (each within the scatter of the next); then compound 1.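

In this assay, putting fluoro in place of ethyl on an aromatic carbon para to a large group gives a number 19.1 percentage points lower from compound 1 to compound 3 (beyond the scatter), the first step measured at a single place in this set. It shows that growth inhibition responds to the group at this position, something compound 1 and compound 2 could not show, as they differ in more than one place. The data shown offer no explanation for this drop.

As far as these compounds go, whether an amine, a carboxylic acid or a longer chain at this position would keep, raise or lower the inhibition of compound 1 remains open. With only one concentration shown, it also remains open how compound 1 and compound 3 would compare at other concentrations.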